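A few compounds are considered here, and "the series" means these few. Any claim that something is new, unique, unknown or untested is made for them only; others in the source may bear on it.

In a functional assay on C8166 cells (Homo sapiens) for cytotoxicity, read by MTT assay, with a stated time of 72 h (on this read-out higher numbers stand for lower toxicity in this test and lower numbers for higher toxicity in this test), the series reads so far:
compound 1 `Cc1ccc(S(=O)(=O)N2CC3(C[C@H]2C(=O)N/N=C/c2ccccc2F)SCCS3)cc1` gives 280000 nM
compound 2 `COc1cc(/C=N/NC(=O)[C@@H]2CC3(CN2S(=O)(=O)c2ccc(C)cc2)SCCS3)cc(OC)c1OC` gives 327000 nM
compound 3 `COc1ccccc1/C=N/NC(=O)[C@@H]1CC2(CN1S(=O)(=O)c1ccc(C)cc1)SCCS2` gives 388000 nM

Compound 3 at 388000 nM stands within the scatter of both other compounds (see a 1.4-fold higher number from compound 1 to compound 3 (0.14 log units; within the scatter) and a 1.2-fold higher number from compound 2 to compound 3 (0.07 log units; within the scatter)). The next compound is compound 4 `Cc1ccc(S(=O)(=O)N2CC3(C[C@H]2C(=O)N/N=C/c2ccccc2Br)SCCS3)cc1` with bromo in place of methoxy on an aromatic carbon, ortho to a large group (bromo in place of methoxy on an aromatic carbon). The same difference reads 2-methoxyphenyl to 2-bromophenyl.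

The closest measured change is methoxy in place of fluoro on an aromatic carbon (a 1.4-fold higher number from compound 1 to compound 3 (0.14 log units; within the scatter)), which stays within the scatter. The exchange of whole aryl groups also stays within it (a 1.2-fold higher number from compound 1 to compound 2 (0.07 log units; within the scatter)). Within the data shown here, no bromo compound has been measured, so this exact exchange remains untested. No step beyond the scatter is therefore expected in this assay, and no firm direction can be given. The estimated step is small (a 1.3-fold lower number from compound 3 to compound 4 (0.11 log units; within the scatter)). Compound 4 is estimated at 300000 nM (expected range 180000 nM to 480000 nM).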

Compound 4, half-maximal cytotoxic concentration: 177000 nM
Estimate against measurement, compound 4: 1.7-fold (0.23 log units) above; the whole stated range lies above it.
By their numbers in this assay, from the lowest: compounds 4, 1, 2 and 3 (each within the scatter of the next, the first and the last beyond it).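

In this assay, among these compounds, bromo in place of methoxy on an aromatic carbon, ortho to a large group, gives the only step that lies beyond the scatter (a 2.2-fold lower number from compound 3 to compound 4 (0.34 log units; beyond the scatter)), and it is a modest one. Among the compounds shown here, this position can therefore separate two compounds in this test, though only this pair shows it: bromo in place of fluoro (a 1.6-fold lower number from compound 1 to compound 4 (0.20 log units; within the scatter)) and 2-bromophenyl in place of 3,4,5-trimethoxyphenyl (a 1.8-fold lower number from compound 2 to compound 4 (0.27 log units; within the scatter)) both stay within the scatter. No measurement at hand accounts for the step.

From the compounds shown here alone, whether chloro, an amine or a carboxylic acid on this aromatic carbon would fall with bromo or with methoxy remains open. Also open, going by these compounds, is whether the same exchange would read alike with a different group on the sulfonyl side of the core.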